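The compounds below may be only part of what the source reports. "The series", "measured", "known", "first", "only" and "open" are said of these compounds alone.

Working notes on the shared core. In a functional assay on U-87MG ATCC cells (Homo sapiens) for cytotoxicity, read by MTT assay, with a stated time of 72 h (on this read-out higher numbers stand for weaker inhibition and lower numbers for stronger inhibition), compound 1 `COc1ccc(/C=N/NC(=O)Nc2ccc(Oc3ccnc(-c4nncn4CCN(C)C)c3)c(F)c2)c(OC)c1OC` gives 7650 nM; compound 2 `CN(C)CCn1cnnc1-c1cc(Oc2ccc(NC(=O)N/N=C/c3ccccc3O[N+](=O)[O-])cc2F)ccn1` gives 7150 nM; compound 3 `CN(C)CCn1cnnc1-c1cc(Oc2ccc(NC(=O)N/N=C/c3ccccc3)cc2F)ccn1` gives 2250 nM, the lowest of the three numbers. The steps of a 3.4-fold lower number from compound 1 to compound 3 (0.53 log units; beyond the scatter) and a 3.2-fold lower number from compound 2 to compound 3 (0.50 log units; beyond the scatter) run the same way: stripping the substituents from the phenyl on the carbon with a double bond to nitrogen lowered the number. Compound 4 `CN(C)CCn1cnnc1-c1cc(Oc2ccc(NC(=O)N/N=C/c3ccc(F)cc3F)cc2F)ccn1` differs from compound 3 by 2,4-difluorophenyl in place of phenyl on a carbon with a double bond to nitrogen. For the measured compounds named here, no measured step places fluorine on this ring, so those two steps bear only loosely; they suggest substituents here raise the number, and a modest rise, or none beyond the scatter, is expected for compound 4 in this assay, about a 1.6-fold higher number from compound 3 to compound 4 (0.19 log units; within the scatter). The estimate for compound 4 is 3500 nM, within 1500 nM to 9000 nM.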

Compound 4, half-maximal inhibitory concentration: 1900 nM
The estimate for compound 4 lay 1.8-fold (0.27 log units) above the measured number; measured number inside the range.
By their numbers in this assay, from the lowest: compounds 4 and 3 (each within the scatter of the next); then compounds 2 and 1 (each within the scatter of the next).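

In this assay, 2,4-difluorophenyl and phenyl on the carbon with a double bond to nitrogen cannot be told apart: a 1.2-fold lower number from compound 3 to compound 4 (0.07 log units; within the scatter). A substituted ring therefore need not carry a higher number, since a 3.8-fold lower number from compound 2 to compound 4 (0.58 log units; beyond the scatter) and a 4.0-fold lower number from compound 1 to compound 4 (0.60 log units; beyond the scatter) both lie beyond the scatter, as the corresponding steps to the phenyl compound 3 do. Nothing available explains why fluorine differs here from nitrooxy or methoxy.

On these data alone, whether a ring bearing an amine or a carboxylic acid would stay level with phenyl remains open. So does whether a single fluorine would behave as the pair does.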